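The source may report more compounds than this note shows. Statements on the series, on what has been measured and on what is new or still open speak of the compounds shown alone.

In a functional assay on SiHa cells (Homo sapiens) for antiproliferative activity, read by CCK-8 assay, with a stated time of 72 h (on this read-out lower numbers stand for stronger inhibition and higher numbers for weaker inhibition), compound 1 `COc1ccc(-c2cncnc2-c2cc(OC)c(OC)c(OC)c2)cc1O` gives 2750 nM, the second highest of three numbers, with compound 2 `CCOc1ccc(-c2cncnc2-c2cc(OC)c(OC)c(OC)c2)cc1Cl` at 150 nM and compound 3 `CCOc1ccc(-c2cncnc2-c2cc(OC)c(OC)c(OC)c2)cc1C(F)(F)F` at 20000 nM. Compound 4 `COc1ccc(-c2cncnc2-c2cc(OC)c(OC)c(OC)c2)nc1` carries 5-methoxypyridin-2-yl in place of 3-hydroxy-4-methoxyphenyl on the core of compound 1: 5-methoxypyridin-2-yl in place of 3-hydroxy-4-methoxyphenyl on an aromatic carbon. For the measured compounds named here, the only measured step, a 130-fold higher number from compound 2 to compound 3 (2.12 log units; beyond the scatter), is trifluoromethyl in place of chloro, a different exchange. It bears only indirectly, showing that one substituent change in this small set can be large. Going by the values given here, no measured step replaces the ring itself, so no direction is supported. The expected step is a 1.3-fold higher number from compound 1 to compound 4 (0.10 log units; within the scatter), none beyond the scatter. For compound 4 the estimated value is 3500 nM, with an expected range of 600 nM to 20000 nM.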

Compound 4, half-maximal inhibitory concentration: 1750 nM
Compound 4: middle estimate off by 2.0-fold (0.30 log units), on the high side; low and high end bracket the measured number.
By their numbers in this assay, from the lowest: compound 2; then compounds 4 and 1 (each within the scatter of the next); then compound 3.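

In this assay, replacing the whole 3-hydroxy-4-methoxyphenyl ring with 5-methoxypyridin-2-yl at this place, ortho to a large group, gives a 1.6-fold lower number from compound 1 to compound 4 (0.20 log units; within the scatter) and leaves the two compounds within the scatter of each other. For the compounds shown here, this is the first exchange of the ring itself, and it shows that the ring can take a nitrogen and lose its hydrogen-bond donor together with no difference that this read-out can separate. No measured evidence explains this result.

The compounds shown leave open how each of those two differences acts alone. They also leave open how a pyridine ring carrying an amine or a longer ether chain in place of methoxy would read at this position.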